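The source may report more compounds than this note shows. Statements on the series, on what has been measured and on what is new or still open speak of the compounds shown alone.

Among the compounds with values here, in a toxicity assay on L02 cells (Homo sapiens) for cytotoxicity, read by MTT assay, with a stated time of 24 h (on this read-out higher numbers stand for lower toxicity in this test and lower numbers for higher toxicity in this test), compound 1 (`CCCCS(=O)(=O)Oc1ccc(/C=C/C(=O)Nc2ccccc2)cc1OC`) gives 3320 nM, the lowest of the three numbers measured so far. Compound 3 (`COc1cc(/C=C/C(=O)Nc2ccc(I)cc2)ccc1OS(=O)(=O)c1ccc(Cl)cc1`) gives 39400 nM and compound 2 (`COC(=O)/C=C/c1ccc(OS(=O)(=O)c2ccc(Cl)cc2)c(OC)c1`) gives 99500 nM. Compound 4 (`CCCCS(=O)(=O)Oc1ccc(/C=C/C(=O)Nc2ccccc2I)cc1OC`) differs from compound 1 by iodo in place of hydrogen on an aromatic carbon, ortho to a large group. Within the data shown here, the only measured step that bears on this is a 2.5-fold lower number from compound 2 to compound 3 (0.40 log units; beyond the scatter), and it replaces methoxy rather than hydrogen, so it is a loose guide. Little change is therefore expected, leaning upward because compound 1 sits lowest with 3320 nM. The expected step is a 1.4-fold higher number from compound 1 to compound 4 (0.13 log units; within the scatter). For compound 4 the estimate is 4500 nM, with an expected range of 1400 nM to 16000 nM.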

Compound 4, half-maximal cytotoxic concentration: 24500 nM
The estimate for compound 4 lay 5.4-fold (0.74 log units) below the measured number; the whole stated range lies below it.
By their numbers in this assay, from the lowest: compound 1; then compounds 4 and 3 (each within the scatter of the next); then compound 2.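

Going from phenyl to 2-iodophenyl gives a 7.4-fold higher number from compound 1 to compound 4 (0.87 log units; beyond the scatter) in this assay, which is the first reading at this hydrogen. It shows that the number responds clearly to iodo on this aromatic carbon, ortho to a large group, and that the step runs towards lower toxicity in this test. Nothing available explains the size of this step. Going by these compounds, it remains open whether fluoro, chloro or methoxy at the same place would give a similar step. Also open, on these data alone, is how iodo on another carbon of this ring would compare with the same butylsulfonate retained.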